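From an anilide to a secondary amide on the carbonyl

The source may report more compounds than this note shows. Statements on the series, on what has been measured and on what is new or still open speak of the compounds shown alone.

Compound 1 `CN(C(=O)[C@H](CCCCN)NC(=O)[C@H](CCCNC(=N)N)NC(=O)c1ccccc1)[C@@H](C(N)=O)c1ccccc1`: <= 5%
Compound 2 `N=C(N)NCCC[C@H](NC(=O)c1ccccc1)C(=O)N[C@@H](CCCCN)C(=O)N(CC(N)=O)c1ccccc1`: <= 5%

Both compounds were tested in an assay on isolated protein for inhibition of Trypsin (Homo sapiens), read by fluorescence, with a stated time of 15 min, tested at 50 uM; on this read-out higher numbers stand for more inhibition at the one concentration tested (going by the name of the read-out) and lower numbers for less inhibition. Compound 1 returns only a limit of the assay, not a number. Compound 2 likewise returns only a limit of the assay. Between them lies a step that the two limits leave unreadable from compound 1 to compound 2, the change being (carbamoylmethyl)(phenyl)amino in place of (carbamoyl(phenyl)methyl)(methyl)amino on a carbonyl carbon; the only evidence on this step is the limit of <= 5% in this assay, at which 2 of the 2 values shown sit, so the step cannot be read.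

Compound 3 `N=C(N)NCCC[C@H](NC(=O)c1ccccc1)C(=O)N[C@@H](CCCCN)C(=O)N[C@@H](CC(N)=O)c1ccccc1` differs from compound 2 by (2-carbamoyl-1-phenylethyl)amino in place of (carbamoylmethyl)(phenyl)amino on a carbonyl carbon. Within the data shown here, no measured step with a readable size bears on this change, and compound 2 itself stands at a limit of the assay, so there is nothing in the numbers that points to a rise or a fall beyond the scatter. The expectation is therefore that the step of a number no lower from compound 2 to compound 3 (the limit leaves the size open) stays within the scatter. Compound 3 is estimated at 5% in this assay, within 0% to 15%, most likely again reported only as a limit.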

Compound 3, a percentage reported as inhibition, at one concentration (the size of the read-out at that concentration, not a potency): 7.5%
Compound 3: the middle estimate sits 2.5 percentage points below what was measured, within the range that was stated.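

In this assay, among these compounds, compound 3, at 7.5%, is the only one of the three compounds to return a number rather than a limit of the assay. This gives a step of a number at least 2.5 percentage points higher from compound 2 to compound 3 (that floor lies within the scatter) and one of a number at least 2.5 percentage points higher from compound 1 to compound 3 (that floor lies within the scatter), so the (2-carbamoyl-1-phenylethyl)amino group on this carbonyl carbon, with its defined stereocentre, is not shown to move the read-out beyond the scatter. The step between compound 1 and compound 2 still cannot be read, and the full size of the two new steps stays open, because both of those compounds sit at a limit: the limit of <= 5% in this assay, at which 2 of the 3 values shown sit.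

The compounds shown leave open whether any group on this carbonyl carbon can lift the read-out in this assay clearly beyond the scatter, for instance a carboxylic acid in place of the carbamoyl group of (2-carbamoyl-1-phenylethyl)amino, or a longer chain carrying that carbamoyl group. They also leave open what the opposite configuration at the defined stereocentre of compound 3 would give.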